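Three Phenylsuccinimide Amides and a Methoxyphenyl Newcomer

This account rests on a few compounds, and the source may have more. Where it says the series, first, only, none or still open, it means among the compounds named here.

Measured compounds in a functional assay on the whole organism (strain CD-1) with Mus musculus as the target, in the maximal electroshock model, with a stated time of 2 h; on this read-out higher numbers stand for an effect only at larger amounts of compound and lower numbers for an effect already at smaller amounts:
compound 1 `Cc1cccc(N2CCN(C(=O)CN3C(=O)CC(C)(c4ccccc4)C3=O)CC2)c1`: 300 mg/kg
compound 2 `CC1(c2ccccc2)CC(=O)N(CC(=O)N2CCN(c3cccc(Cl)c3)CC2)C1=O`: 300 mg/kg
compound 3 `CC1(c2ccccc2)CC(=O)N(CC(=O)N2CCC(Cc3ccccc3)CC2)C1=O`: 300 mg/kg

Compound 2 stands level with compound 1 and compound 3 at the digits shown, its nearest neighbour being compound 1 and its furthest compound 3, both within the scatter. Compound 4 `COc1ccccc1N1CCN(C(=O)CN2C(=O)CC(C)(c3ccccc3)C2=O)CC1` differs from compound 2 by 2-methoxyphenyl in place of 3-chlorophenyl on an amine nitrogen in a ring. For the measured compounds named here, the only measured step on an aromatic substituent, no change at the digits printed from compound 1 to compound 2 (within the scatter), is the one that bears on this change, and it lay within the scatter. Going by the values given here, no measured step covers a methoxy group or its position on the ring, so nothing in hand points either way. Compound 4 is therefore expected to stay about where compound 2 is, with an estimated no change at the digits printed from compound 2 to compound 4 (within the scatter), giving an estimated 300 mg/kg within a range of 100 mg/kg to 600 mg/kg.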

Compound 4, minimum effective dose: 300 mg/kg
The estimate for compound 4 equals the measured number at the digits printed; the range from low to high includes it.
By their numbers in this assay, from the lowest: compounds 1, 2, 3 and 4 (each within the scatter of the next).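

In this assay, swapping the aromatic group on the amine nitrogen in a ring for one with a different substituent, at a different place on the phenyl ring, gives no change at the digits printed from compound 2 to compound 4 (within the scatter) and no change at the digits printed from compound 1 to compound 4 (within the scatter). The 2-methoxyphenyl adds a hydrogen-bond acceptor that the 3-chlorophenyl lacks, and this read-out does not register the difference. Nothing at hand offers an explanation for this result. Going by these compounds, whether an amine or a carboxylic acid on that aromatic ring would shift the read-out remains open.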